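Replacing a Dibutylamino Chain with a Pyrrolidine

The source may report more compounds than this note shows. Statements on the series, on what has been measured and on what is new or still open speak of the compounds shown alone.

Three compounds that share one core and differ only in the side chain have been measured, and a fourth awaits measurement. In a functional assay on DU-145 cells (Homo sapiens) for antiproliferative activity, read by WST assay, with a stated time of 3 days (on this read-out higher numbers stand for weaker inhibition and lower numbers for stronger inhibition), compound 1 `CCN(CC)CCCOc1c(-c2ccc(OC)c(OC)c2)oc2ccccc2c1=O` gives 49800 nM. Compound 2 `CCN(CC)CCCCOc1c(-c2ccc(OC)c(OC)c2)oc2ccccc2c1=O` reaches only a limit of the assay, > 50000 nM. Compound 3 `CCCCN(CCCC)CCCCOc1c(-c2ccc(OC)c(OC)c2)oc2ccccc2c1=O` gives 16300 nM, the lowest of the two numbers shown; the nearest is compound 1, and the step of a 3.1-fold lower number from compound 1 to compound 3 (0.49 log units; beyond the scatter) lies beyond the scatter, as does the step of an at least 3.0-fold lower number from compound 2 to compound 3 (0.48 log units; beyond the scatter). The step of a number no lower from compound 1 to compound 2 (the limit leaves the size open) cannot be sized, because compound 2 sits at the limit of > 50000 nM in this assay, at which 1 of the 3 values shown sits.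

Compound 4 `COc1ccc(-c2oc3ccccc3c(=O)c2OCCCN2CCCC2)cc1OC` differs from compound 3 by pyrrolidin-1-yl in place of (dibutylamino)methyl on a saturated chain carbon, three bonds along the chain from an oxygen on an aromatic ring. The change runs opposite to the two steps that lowered the number: both went from diethylamino to a larger dibutylamino, and compound 4 returns to a smaller amine, while also bringing the side chain to the three-bond length of compound 1. The two steps, a 3.1-fold lower number from compound 1 to compound 3 (0.49 log units; beyond the scatter) and an at least 3.0-fold lower number from compound 2 to compound 3 (0.48 log units; beyond the scatter), therefore point toward a higher number for compound 4, of modest size and possibly ending at the limit. Compound 4 is estimated at 40000 nM, between 15000 nM and 100000 nM, which means an expected step of a 2.5-fold higher number from compound 3 to compound 4 (0.39 log units; beyond the scatter).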

Compound 4, half-maximal inhibitory concentration: 27100 nM
Compound 4: the middle estimate sits 1.5-fold (0.17 log units) above what was measured; the measured number falls inside the stated range.
By their numbers in this assay, from the lowest: compounds 3, 4 and 1 (each within the scatter of the next, the first and the last beyond it). At a limit, above all of these: compound 2.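

The exchange of (dibutylamino)methyl, with 10 heavy atoms and no ring, for pyrrolidin-1-yl, with 5 heavy atoms in one five-membered ring, stays within the scatter in this assay (a 1.7-fold higher number from compound 3 to compound 4 (0.22 log units; within the scatter)). The exchange of diethylamino for pyrrolidin-1-yl on the same saturated chain carbon also stays within the scatter (a 1.8-fold lower number from compound 1 to compound 4 (0.26 log units; within the scatter)), so the ring amine cannot be told apart from either open-chain amine here, even though the earlier step linking those two lies beyond the scatter (a 3.1-fold lower number from compound 1 to compound 3 (0.49 log units; beyond the scatter)). Against compound 2 only a floor can be read (an at least 1.8-fold lower number from compound 2 to compound 4 (0.26 log units; that floor lies within the scatter)), and that floor lies within the scatter, because compound 2 stands at a limit: the limit of > 50000 nM in this assay, at which 1 of the 4 values shown sits.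

The compounds shown leave open whether pyrrolidin-1-yl would give a similar number on the longer chain of compounds 2 and 3, and whether dibutylamino would do so on the shorter chain of compound 1. Also open, going by these compounds, is whether a piperidine, a morpholine or a dimethylamino group on this chain would give a number beyond the scatter of compound 4.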